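This account rests on a few compounds, and the source may have more. Where it says the series, first, only, none or still open, it means among the compounds named here.

Of the compounds shown here, two have so far been measured in an ADME assay (liver) for pharmacokinetics, with Liver microsome (Rattus norvegicus) as the target, read by LC-MS, using microsomes, tested at 2 uM; a higher number here means faster removal of the compound, a lower number slower removal. Compound 1 `O=C(N[C@@H]1CCCC[C@H]1O)c1cnc(OCC(F)(F)F)c(-c2ccc(Cl)cc2)c1` gives 0.023 mL/min/kg in this assay, the higher of the two numbers. Compound 2 `C[C@](O)(CNC(=O)c1cnc(OCC2CC2)c(-c2ccc(Cl)cc2)c1)C1CC1` gives 0.0024 mL/min/kg, a lower number, and the gap between compound 2 and compound 1 lies beyond the scatter. Compound 3 `O=C(N[C@@H]1CCCC[C@H]1O)c1cnc(CCC2CC2)c(-c2ccc(Cl)cc2)c1` has not yet been measured. It differs from compound 1 in one place: 2-cyclopropylethyl in place of 2,2,2-trifluoroethoxy on an aromatic carbon, the change sitting on an aromatic carbon of a six-membered aromatic ring with one nitrogen, next to the ring nitrogen and ortho to a 4-chlorophenyl group. Going by the values given here, no pair of measured compounds shows this change, so nothing in the numbers fixes its size or direction. A moderate rise is nevertheless expected, with considerable uncertainty, as a 1.7-fold higher number from compound 1 to compound 3 (0.24 log units; within the scatter). Compound 3 is accordingly estimated at 0.04 mL/min/kg in this assay, within a range from 0.012 mL/min/kg to 0.12 mL/min/kg.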

Compound 3, clearance: 1.5 mL/min/kg
Compound 3: the middle estimate sits 38-fold (1.57 log units) below what was measured; the whole stated range lies below it.
By their numbers in this assay, from the lowest: compound 2; then compound 1; then compound 3.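

In this assay, the position next to the ring nitrogen and ortho to a 4-chlorophenyl group proves highly sensitive to the group it carries: 2-cyclopropylethyl in place of 2,2,2-trifluoroethoxy gives a 65-fold higher number from compound 1 to compound 3 (1.81 log units; beyond the scatter). With the rest of compound 1 held fixed, this step shows that a change at this one position is enough to move the clearance by a large amount. Nothing measured here accounts for the size of the step.

The change removes the oxygen and the three fluorines and adds a cyclopropyl ring all at once, and the compounds shown do not separate these parts. They also leave open where a plain ethoxy group, a propyl chain or an amine at this position would fall.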